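A Fluorine Swap Tested on a Second Core

The source may report more compounds than this note shows. Statements on the series, on what has been measured and on what is new or still open speak of the compounds shown alone.

Two pairs of compounds share one structural change. Compound 1 `N#Cc1cccc(COc2ccc(-c3cc(CN4CCN(Cc5ccc(C(F)(F)F)cc5)CC4)no3)cc2)c1` and compound 3 `N#Cc1cccc(COc2ccc(-c3cc(CN4CCN(Cc5ccc(C(F)(F)F)cc5)CC4)no3)cc2F)c1` differ only in this way: fluoro in place of hydrogen on an aromatic carbon In a functional assay on Mahlavu cells (Homo sapiens) for antiproliferative activity, read by sulforhodamine B assay, with a stated time of 72 h (on this read-out higher numbers stand for weaker inhibition and lower numbers for stronger inhibition), compound 1 gives 10600 nM, while compound 3 gives 500 nM, a move of a 21-fold lower number from compound 1 to compound 3 (1.33 log units; beyond the scatter). Compound 2 `N#Cc1cccc(COc2ccc(-c3cc(CNC4CCN(Cc5ccccc5)CC4)no3)cc2)c1` carries a different core; the difference between the two cores is not broken down here. In this assay compound 2 gives 2100 nM, a number that lies between those of compound 1 and compound 3. Compound 4 `N#Cc1cccc(COc2ccc(-c3cc(CNC4CCN(Cc5ccccc5)CC4)no3)cc2F)c1` has not yet been measured and differs from compound 2 in the same way: fluoro in place of hydrogen on an aromatic carbon The place of the change is described in the same words for both pairs, so it counts as the same change. Compound 4 is expected to give 350 nM in this assay. Within the data shown here, the expected step from compound 2 to compound 4 is a 6.0-fold lower number from compound 2 to compound 4 (0.78 log units; beyond the scatter), set a little below the earlier one, as only one measured pair supports it. That expectation rests on compound 3, whose pair showed a 21-fold lower number from compound 1 to compound 3 (1.33 log units; beyond the scatter). Compound 4 is estimated to fall between 120 nM and 1000 nM.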

Compound 4, half-maximal inhibitory concentration: 2700 nM
For compound 4 the middle estimate is 7.7-fold (0.89 log units) below the measured one; measured number outside the range, above it.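

In this assay, putting fluoro in place of hydrogen on the core of compound 2 gives a 1.3-fold higher number from compound 2 to compound 4 (0.11 log units; within the scatter) and so makes no readable difference, even though the same swap mattered greatly on the core of compound 1. This shows that the effect of the change cannot be assumed to carry over from one core to another in this series, since it depends on the core that carries it. What it does not show is which part of the cores is responsible, or why, as the two cores differ in more than one place and each core offers only a single pair, and the two steps clearly differ: the same change on two cores in this assay, a 21-fold lower number (1.33 log units; beyond the scatter) from compound 1 to compound 3 and a 1.3-fold higher number (0.11 log units; within the scatter) from compound 2 to compound 4, 27-fold (1.44 log units) apart, beyond the scatter of two such steps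

The compounds shown leave open whether a chloro or a methoxy group in that same place would behave as fluoro does on each core. They also leave open how the swap would fare on a core that carries only some of the features separating the two cores, which could show which feature decides the outcome.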